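The compounds below may be only part of what the source reports. "The series", "measured", "known", "first", "only" and "open" are said of these compounds alone.

Measured so far in a functional assay on HL-60 cells (Homo sapiens) for cytotoxicity, read by WST assay, with a stated time of 48 h; a lower number here means that less compound is needed, a higher number that more compound is needed for the effect:
compound 1 `COCOc1ccccc1C[C@H]1C(=O)OC[C@@H]1Cc1ccccc1`: 76000 nM
compound 2 `O=C1OC[C@H](Cc2ccccc2)[C@H]1Cc1ccccc1C(F)(F)F`: 37000 nM
compound 3 `O=C1OC[C@H](Cc2ccccc2)[C@H]1Cc1cccc(O)c1`: > 100000 nM

For compound 3 only a limit is known, (the limit of > 100000 nM in this assay, at which 1 of the 3 values shown sits), so no number stands for it. Compound 4 `O=C1OC[C@H](Cc2ccccc2)[C@H]1Cc1ccc(Cl)cc1` differs from compound 3 in one place: 4-chlorophenyl in place of 3-hydroxyphenyl on a saturated chain carbon bound to a saturated ring carbon. For the measured compounds named here, the single measured step, a 2.1-fold lower number from compound 1 to compound 2 (0.31 log units; beyond the scatter), concerns other groups on the aromatic ring and therefore offers no direct guide; it shows only that exchanging one substituent there shifted this assay modestly. Compound 2 gives 37000 nM in this assay, and compound 4 is expected in a similar region. The step expected is an at least 2.0-fold lower number from compound 3 to compound 4 (0.30 log units; that floor lies within the scatter). Compound 4 is estimated at 50000 nM, within a range from 20000 nM to 150000 nM.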

Compound 4, half-maximal effective concentration: 36000 nM
Compound 4: the middle estimate sits 1.4-fold (0.14 log units) above what was measured; the range from low to high includes it.
By their numbers in this assay, from the lowest: compounds 4 and 2 (each within the scatter of the next); then compound 1. At a limit, above all of these: compound 3.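

At this place, on a saturated chain carbon bound to a saturated ring carbon, 4-chlorophenyl in place of 3-hydroxyphenyl gives an at least 2.7-fold lower number from compound 3 to compound 4 (0.44 log units; beyond the scatter) in this assay. That size is only a floor, and compound 3 stands at a limit: the limit of > 100000 nM in this assay, at which 1 of the 4 values shown sits. The step cannot tell whether the missing hydroxyl, the added chlorine or their different places on the ring matter most.

On these data alone, it remains open how an amine or a carboxylic acid on this aromatic ring would read in this assay.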